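Swapping the 2-carboxyethyl group on a shared core

The source may hold more compounds than are shown below. What is called first, only, known or untested is meant among the compounds shown, and "the series" means these compounds.

In a functional assay with Oryctolagus cuniculus as the target (on this read-out lower numbers stand for stronger inhibition and higher numbers for weaker inhibition), compound 1 `CNC(=N)Nc1nc(-c2ccc(OC)cc2)c(-c2ccc(OC)cc2)s1` gives 62 nM and compound 2 `COc1ccc(-c2nc(/N=C(\N)N(C)C)sc2-c2ccc(OC)cc2)cc1` gives 37 nM. The step between them, a 1.7-fold lower number from compound 1 to compound 2 (0.22 log units; within the scatter), is the only one of readable size. Compound 3 `COc1ccc(-c2nc(CCC(=O)O)sc2-c2ccc(OC)cc2)cc1`, which carries the 2-carboxyethyl group, is known only as a limit, < 100 nM. Going by these compounds, its exact place on the scale therefore remains open. The other two steps, a step that the limit leaves unreadable from compound 1 to compound 3 and a step that the limit leaves unreadable from compound 2 to compound 3, have no size because of the limit of < 100 nM in this assay, at which 1 of the 3 values shown sits.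

Compound 4 `COc1ccc(-c2nc(C3=NNC(=O)CC3)sc2-c2ccc(OC)cc2)cc1` has not yet been measured. It differs from compound 3 in one place: a group of 7 heavy atoms (4 carbon, 2 nitrogen, 1 oxygen; one six-membered non-aromatic ring with 2 hetero atoms) in place of a group of 5 heavy atoms (3 carbon, 2 oxygen; no ring), on an aromatic carbon. The 2-carboxyethyl group leaves the aromatic carbon, and a group with a six-membered non-aromatic ring enters. All three measured steps change the group on an aromatic carbon, but only one gives a usable size, and that step stays within the scatter. Going by the values given here, no measured step involves a ring entering at this place, so the expectation is loose and no direction can be given. The estimated change is a step that the limit leaves unreadable from compound 3 to compound 4, and no step beyond the scatter is expected in this assay. The expected value for compound 4 is 60 nM, within an estimated range of 15 nM to 250 nM.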

Compound 4, half-maximal inhibitory concentration: > 1000 nM
Compound 4 was reported as a limit; the forecaster's own chance of this, stated with the estimate: 30%; middle value at least 16-fold (1.22 log units) away from the limit.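

In this assay, going by these compounds alone, this position, on an aromatic carbon next to the ring nitrogen and next to the ring sulfur, now shows that the group it carries can matter: the only step readable before, a 1.7-fold lower number from compound 1 to compound 2 (0.22 log units; within the scatter), gave no change beyond the scatter. Within the data shown here, with the six-membered non-aromatic ring entering in place of the 2-carboxyethyl group, the result is an at least 10-fold higher number from compound 3 to compound 4 (1.00 log units; beyond the scatter), and the comparisons with the two open-chain nitrogen groups give an at least 27-fold higher number from compound 2 to compound 4 (1.43 log units; beyond the scatter) and an at least 16-fold higher number from compound 1 to compound 4 (1.20 log units; beyond the scatter), which makes this ring the one change here that sets a compound clearly apart from all the others. The value of compound 4, > 1000 nM, is a limit.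

Going by these compounds, the steps from compound 1 and from compound 2 to compound 3 still cannot be read because of a limit: the limit of < 100 nM in this assay, at which 1 of the 4 values shown sits. What a plain amine or a carboxylic acid on a shorter chain would give at this position stays open, as does whether a ring of another size would behave like the six-membered one.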